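Amide aryl variation on the shared core: toward compound 4

The compounds below may be only part of what the source reports. "The series", "measured", "known", "first", "only" and "open" are said of these compounds alone.

Measured in a functional assay on MCF7 cells (Homo sapiens) for antiproliferative activity, read by MTT assay, with a stated time of 72 h; on this read-out higher numbers stand for weaker inhibition and lower numbers for stronger inhibition:
compound 1 `CCN1CCN(c2cc(C)c3cc(NC(=O)c4ccc(F)cc4)ccc3n2)CC1`: 4030 nM
compound 2 `CCN1CCN(c2cc(C)c3cc(NC(=O)c4ccc[nH]4)ccc3n2)CC1`: 14700 nM
compound 3 `CCN1CCN(c2cc(C)c3cc(NC(=O)c4ccccc4C)ccc3n2)CC1`: 10900 nM

Compound 1 gives the lowest number of the three; the nearest is a 2.7-fold higher number from compound 1 to compound 3 (0.43 log units; beyond the scatter) and the furthest a 3.6-fold higher number from compound 1 to compound 2 (0.56 log units; beyond the scatter). Compound 4 `CCN1CCN(c2cc(C)c3cc(NC(=O)c4ccc5ccccc5n4)ccc3n2)CC1` has not yet been measured; it differs from compound 1 by quinolin-2-yl in place of 4-fluorophenyl on a carbonyl carbon. Among the compounds with values here, both measured steps away from the 4-fluorophenyl group went to higher numbers, so that direction is the more likely outcome, but neither replacement resembles a quinolin-2-yl group closely, and a group with a six-membered aromatic ring carrying one hetero atom has no precedent in this set. The expected step is a 1.5-fold higher number from compound 1 to compound 4 (0.17 log units; within the scatter), with wide uncertainty. Compound 4 is estimated at 6000 nM, range 1500 nM to 25000 nM.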

Compound 4, half-maximal inhibitory concentration: 7060 nM
Compound 4: the middle estimate sits 1.2-fold (0.07 log units) below what was measured; the range from low to high includes it.
By their numbers in this assay, from the lowest: compounds 1, 4, 3 and 2 (each within the scatter of the next, the first and the last beyond it).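

On the carbonyl carbon, quinolin-2-yl brings more heavy atoms and a hydrogen-bond acceptor, yet the result is only a 1.8-fold higher number from compound 1 to compound 4 (0.24 log units; within the scatter) and a 1.5-fold lower number from compound 3 to compound 4 (0.19 log units; within the scatter). Only the comparison with the 1H-pyrrol-2-yl group separates, at a 2.1-fold lower number from compound 2 to compound 4 (0.32 log units; beyond the scatter), so adding a second aromatic ring with one ring nitrogen does not move the number beyond the scatter of the 4-fluorophenyl value. No measured data shown here explain these differences.

Open, from the compounds shown here alone, is whether a pyridin-2-yl group, carrying the ring nitrogen on a single ring, would match compound 4. Also open, going by these compounds, is whether a carboxylic acid or an amine on the aromatic group would give a number clearly lower than that of compound 1.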